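Ester in place of acid on the fluorinated benzofuran amide

The source may hold more compounds than are shown below. What is called first, only, known or untested is meant among the compounds shown, and "the series" means these compounds.

Compound 1: `CC(C)(NC(=O)c1cccc2c(Br)c(-c3ccc(Cl)cc3)oc12)C(=O)O` gives 1760 nM
Compound 2: `C[C@H](NC(=O)c1cc(F)cc2cc(-c3ccc(Cl)cc3)oc12)C(=O)O` gives 4440 nM
Compound 3: `O=C(NC1(C(=O)O)CCCCC1)c1cccc2c(Br)c(-c3ccc(Cl)cc3)oc12` gives 151 nM

In an assay on isolated protein for inhibition of endoplasmic reticulum aminopeptidase 1 (Homo sapiens), with stated times of 15 min and 20 min (on this read-out higher numbers stand for weaker inhibition and lower numbers for stronger inhibition), compound 2 stands highest of the three numbers; compound 1 is its nearest neighbour, and compound 3 lies furthest from it. Going by the values given here, the only step between measured compounds that differ in one place is a 12-fold lower number from compound 1 to compound 3 (1.07 log units; beyond the scatter), and it concerns the group on the amide-type nitrogen, the same place that changes here.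

Compound 4 is `COC(=O)C(C)(C)NC(=O)c1cc(F)cc2cc(-c3ccc(Cl)cc3)oc12`. The difference from compound 2 is 1-(methoxycarbonyl)-1-methylethyl in place of 1-carboxyethyl on an amide-type nitrogen. Among the compounds with values here, no measured pair shows a carboxylic acid exchanged for a methyl ester, and no measured pair shows 1-carboxyethyl exchanged for a 1-methylethyl type group; the step from compound 1 to compound 3 touches the same nitrogen but with other groups, so it gives only a loose guide to how much this place can move the number. The direction of that step cannot be carried over to a change that removes the hydrogen-bond donor. The expectation therefore rests on compound 2 alone as the anchor, with a wide range and a real chance that only a limit is reported. Compound 4 is expected to show a 3.4-fold higher number from compound 2 to compound 4 (0.53 log units; beyond the scatter), giving an estimated 15000 nM within 4000 nM to 60000 nM.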

Compound 4, half-maximal inhibitory concentration: > 10000 nM
Compound 4: no number, only a limit; the forecaster's own chance of this, stated with the estimate: 30%; the middle value does not contradict the limit.
By their numbers in this assay, from the lowest: compound 3; then compound 1; then compound 2. At a limit, above all of these: compound 4.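

Compound 4 gives no number in this assay, only a limit: the limit of > 10000 nM in this assay, at which 1 of the 4 values shown sits.

Even so, the result gives an at least 2.2-fold higher number from compound 2 to compound 4 (0.35 log units; beyond the scatter), so 1-(methoxycarbonyl)-1-methylethyl in place of 1-carboxyethyl on the amide-type nitrogen moves the number upward beyond the scatter. The earlier step at this nitrogen, a 12-fold lower number from compound 1 to compound 3 (1.07 log units; beyond the scatter), went the other way, so the group on this nitrogen is now seen to shift the number in both directions, although that earlier step sits on the core of compound 1 and involves other groups.

The entering group differs from the leaving one both in the methyl ester and in the extra methyl on the carbon bound to the nitrogen, and the compounds shown do not separate these two changes, nor do they give the full size of the step, which remains a limit. They also leave open how this position would respond on the core of compound 2 to 1-carboxy-1-methylethyl, to 1-carboxycyclohexyl, or to a primary carboxamide in place of the carboxylic acid.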